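The source may report more compounds than this note shows. Statements on the series, on what has been measured and on what is new or still open speak of the compounds shown alone.

In a functional assay for inhibition of Polyunsaturated fatty acid 5-lipoxygenase (Homo sapiens) (on this read-out higher numbers stand for weaker inhibition and lower numbers for stronger inhibition), compound 1 `CC/C(=N\OC(c1ccc(OCc2ccc3ccccc3n2)cc1)C1CCCCC1)C(=O)O` gives 30 nM, compound 2 `O=C(O)/C(CSCCO)=N/OC(c1ccc(OCc2ccc3ccccc3n2)cc1)C1CCCCC1` gives 181 nM, and compound 3 `C=CCC(O/N=C(\C)C(=O)O)c1ccc(OCc2ccc3ccccc3n2)cc1` gives 142 nM. Compound 3 thus holds the second highest of the three numbers: its gap to compound 2 lies within the scatter, while compound 1 stands apart from it beyond the scatter. Compound 4 `C/C(=N\OC(CC(C)(C)c1ccccc1)c1ccc(OCc2ccc3ccccc3n2)cc1)C(=O)O` carries 1-methyl-1-phenylethyl in place of vinyl on a saturated chain carbon, two bonds along the chain from an aromatic carbon and an oxygen on an unsaturated carbon. For the measured compounds named here, the only step measured at a single place, a 6.0-fold higher number from compound 1 to compound 2 (0.78 log units; beyond the scatter), alters a different position, so no measured step bears directly on this change, and compounds 1 and 3 differ in more than one place, so their values alone say nothing about it. The estimate for compound 4 is therefore 130 nM, with a range from 30 nM to 550 nM, which is expected to amount to a 1.1-fold lower number from compound 3 to compound 4 (0.04 log units; within the scatter), no change beyond the scatter.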

Compound 4, half-maximal inhibitory concentration: 22 nM
Beside the measured number, compound 4's estimate is 5.9-fold (0.77 log units) above it; the whole stated range lies above it.
By their numbers in this assay, from the lowest: compounds 4 and 1 (each within the scatter of the next); then compounds 3 and 2 (each within the scatter of the next).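

On a saturated chain carbon, two bonds along the chain from an aromatic carbon and an oxygen on an unsaturated carbon, the change from vinyl to 1-methyl-1-phenylethyl gives a 6.5-fold lower number from compound 3 to compound 4 (0.81 log units; beyond the scatter) in this assay. This shows that this position tolerates the larger group and that inhibition is stronger with it. Nothing available explains this step.

The compounds shown leave open whether the phenyl ring or the two methyl groups of the new substituent account for the step. They also leave open how a plain 2-phenylethyl chain or a pyridine ring in place of the phenyl would read here.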